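The compounds below may be only part of what the source reports. "The series", "measured", "known", "first", "only" and "open" are said of these compounds alone.

Compound 1 `Clc1ccc(-n2cc(CSc3nc4ccccc4s3)nn2)cc1` was tested in a functional assay on the whole organism (strain Albino Wistar) for inhibition, with Rattus norvegicus as the target, read by paw edema, with stated times of 1 h and 5 h, at a dose of 10 mg/kg by the oral route (a lower number here means less inhibition, a higher number more inhibition at the dose given (going by the name of the read-out)), where compound 1 gives 43.4%. Among the measured compounds shown here, of the two numbers measured so far this is the lower one: compound 2 `O=[N+]([O-])c1ccc(-n2cc(CSc3nc4ccccc4s3)nn2)cc1` gives 65.5% in this assay, and the step of a number 22.1 percentage points higher from compound 1 to compound 2 (beyond the scatter) is the only measured step available. Compound 3 `CC1(C)OCC(Cn2cc(CSc3nc4ccccc4s3)nn2)O1` has not yet been measured in this assay. The change from compound 1 to compound 3 is (2,2-dimethyl-1,3-dioxolan-4-yl)methyl in place of 4-chlorophenyl on an aromatic nitrogen. For the measured compounds named here, the single measured step exchanges one substituent on the aromatic ring while keeping that ring in place, whereas the change to compound 3 removes the ring altogether, so that step gives no direct guide and the direction of the new step cannot be read from the data. The step of a number 3.4 percentage points lower from compound 1 to compound 3 (within the scatter) is therefore expected to be small relative to its uncertainty. Compound 3 is estimated to give 40% in this assay, within a range from 20% to 60%.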

Compound 3, a percentage reported as inhibition, in the whole organism at one dose (the size of the read-out at that dose, not a potency): 49.1%
For compound 3 the middle estimate is 9.1 percentage points below the measured one, and the stated range covers the measured number.
By their numbers in this assay, from the lowest: compounds 1 and 3 (each within the scatter of the next); then compound 2.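

On the aromatic nitrogen of the five-membered ring, putting (2,2-dimethyl-1,3-dioxolan-4-yl)methyl in place of 4-chlorophenyl in this assay gives a number 5.7 percentage points higher from compound 1 to compound 3 (within the scatter). The earlier pair only exchanged a substituent on the aromatic ring, whereas this step shows that the whole ring of carbon can give way to a non-aromatic ring with hetero atoms, joined through a methylene, without a change beyond the scatter at this dose. No measurement at hand accounts for this result.

The compounds shown leave open whether the ring oxygens of the dioxolane matter, which a cyclohexylmethyl group on the same nitrogen would address, and how an open-chain diol or a carboxylic acid would behave there. They also leave open whether any non-aromatic group here can match compound 2 at 65.5% in this read-out.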